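Chloro in Place of Trifluoromethyl: Effect on Cell Growth

The source may hold more compounds than are shown below. What is called first, only, known or untested is meant among the compounds shown, and "the series" means these compounds.

Three compounds have been measured in a functional assay on HCC 2998 cells (Homo sapiens) for inhibition, read by sulforhodamine B assay, with a stated time of 48 h, tested at 0.01 uM; on this read-out higher numbers stand for a weaker effect at the one concentration tested and lower numbers for a stronger effect:

Compound 1 `O=C(Nc1cccc(-n2cc(-c3ccncc3)c(-c3cc(O)cc(Cl)c3)n2)c1)Nc1ccc(Cl)c(C(F)(F)F)c1` gives 97%.
Compound 2 `O=C(Nc1cccc(-n2cc(-c3ccncc3)c(-c3cc(O)cc(Cl)c3)n2)c1)Nc1ccc(Cl)c(Cl)c1` gives 104%.
Compound 3 `COc1cc(Cl)cc(-c2nn(-c3cccc(NC(=O)Nc4ccc(Cl)c(C(F)(F)F)c4)c3)cc2-c2ccncc2)c1` gives 95%.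

All three numbers sit close together, so none of the compounds can be called stronger or weaker than another. Compound 1 and compound 2 differ by chloro in place of trifluoromethyl on an aromatic carbon, and the step is a number 7 percentage points higher from compound 1 to compound 2 (within the scatter). Compound 1 and compound 3 differ by methyl in place of hydrogen on an oxygen on an aromatic ring, and that step is a number 2 percentage points lower from compound 1 to compound 3 (within the scatter).

Compound 4 `COc1cc(Cl)cc(-c2nn(-c3cccc(NC(=O)Nc4ccc(Cl)c(Cl)c4)c3)cc2-c2ccncc2)c1` has not yet been measured. It differs from compound 3 by chloro in place of trifluoromethyl on an aromatic carbon, which is the same change already seen between compound 1 and compound 2, at a place described in the same words. Because the earlier step was a number 7 percentage points higher from compound 1 to compound 2 (within the scatter), the step from compound 3 to compound 4 is expected to be of similar size, a number 5 percentage points higher from compound 3 to compound 4 (within the scatter). On that basis compound 4 is estimated to give about 100% in this assay, likely between 88% and 112%.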

Compound 4, a percentage reported as activity, at one concentration (the size of the read-out at that concentration, not a potency): 93%
Beside the measured number, compound 4's estimate is 7 percentage points above it; low and high end bracket the measured number.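

In this assay, chloro in place of trifluoromethyl gives a number 2 percentage points lower from compound 3 to compound 4 (within the scatter), and this step agrees with the same change on the other core, since the two steps differ by no more than two such steps normally scatter: the same change on two cores in this assay, a number 7 percentage points higher (within the scatter) from compound 1 to compound 2 and a number 2 percentage points lower (within the scatter) from compound 3 to compound 4, 9 percentage points apart, within the scatter of two such steps. Methyl in place of hydrogen on the oxygen gives a number 11 percentage points lower from compound 2 to compound 4 (beyond the scatter), a modest step on its own, yet it too cannot be told apart from its counterpart on the other core: the same change on two cores in this assay, a number 2 percentage points lower (within the scatter) from compound 1 to compound 3 and a number 11 percentage points lower (beyond the scatter) from compound 2 to compound 4, 9 percentage points apart, within the scatter of two such steps. Both changes therefore carry from one core to the other without a measurable difference in this small set, but two examples of each, read at a single concentration, do not show that the steps are truly equal or reveal any difference in potency.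

The compounds shown leave open what a nitrile or a fluoro group would do in place of the trifluoromethyl. They also leave open how a longer chain on the oxygen, or an amine in place of the hydroxyl, would read in this assay.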